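Notes on compounds 1 to 3: methoxy removed

The compounds below may be only part of what the source reports. "The series", "measured", "known", "first", "only" and "open" are said of these compounds alone.

Measured in a functional assay on NUGC-3 cells (Homo sapiens) for antiproliferative activity, read by sulforhodamine B assay; a lower number here means a stronger inhibitor of growth, a higher number a weaker inhibitor of growth:
Compound 1, structure `O=C(Nc1cccc([N+](=O)[O-])c1)Nc1nc2ccc(F)cc2s1`, gives 0.83 ug/mL.
Compound 2, structure `COc1ccc(NC(=O)Nc2nc3ccc(F)cc3s2)cc1`, returns only a limit of the assay, > 10 ug/mL.

Compound 2 thus stands at the weak end of the two results shown: its entry is the limit of > 10 ug/mL in this assay, at which 1 of the 2 values shown sits, so no number is known for it, and only compound 1 carries a measured value in this assay. The two compounds differ in more than one place, so the gap between them is not resolved into single steps; what the pair shows is that compound 1 inhibits growth at a measured concentration, while compound 2 does not within the range tested.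

Compound 3, structure `O=C(Nc1ccccc1)Nc1nc2ccc(F)cc2s1`, is the next candidate. Relative to compound 2 the change is hydrogen in place of methoxy on an aromatic carbon. For the measured compounds named here, with compound 2 known only as a limit, no measured step bounds this change, and the direction cannot be read from the data. The expected step in this assay is an at least 2.0-fold lower number from compound 2 to compound 3 (0.30 log units; that floor lies within the scatter), toward stronger inhibition but with a real chance that compound 3 also returns only a limit. Compound 3 is estimated at 5 ug/mL, with a range from 1.5 ug/mL to 10 ug/mL.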

Compound 3, concentration for 50% growth inhibition: > 10 ug/mL
Compound 3: a limit, no number (the forecaster's own chance of this, stated with the estimate: 40%); middle value at least 2.0-fold (0.30 log units) from the limit.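

In this assay compound 3 returns > 10 ug/mL as a limit of the assay and not as a number. Hydrogen in place of nitro on an aromatic carbon gives an at least 12-fold higher number from compound 1 to compound 3 (1.08 log units; beyond the scatter) and is the first readable single change in the series, which ties the measured growth inhibition of compound 1 to the nitro group and not to the shared core alone. With methoxy para to a large group or with hydrogen at that place, the series stays at the weak end, and the step for that change cannot be read, both of its ends being limits: the limit of > 10 ug/mL in this assay, at which 2 of the 3 values shown sit.

Still open, going by these compounds, is how far compound 2 and compound 3 lie past the limit, and whether another group in place of nitro, such as an amine, a nitrile or a trifluoromethyl group, would also bring a measurable value. Also open, on these data alone, is whether nitro needs its own place on the ring, and whether the fluorine on the core has any share in the value of compound 1.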